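Notes on the step from isopropyl to benzyl

The compounds below may be only part of what the source reports. "The series", "measured", "known", "first", "only" and "open" are said of these compounds alone.

Measured so far:
- compound 1 `COC(=O)c1[nH]c2cc(C(F)(F)F)ccc2c1-c1ccc(C(F)(F)F)cc1` gives > 100000 nM as a limit of the assay
- compound 2 `COC(=O)c1[nH]c2cc(OC)ccc2c1C(C)C` gives 81500 nM as a number

Both were read in a functional assay on RS4-11 cells (Homo sapiens) for antiproliferative activity, read by MTT assay, with a stated time of 48 h; on this read-out lower numbers stand for an effect already at smaller amounts and higher numbers for an effect only at larger amounts of compound. Compound 1 has only a limit, so the limit of > 100000 nM in this assay, at which 1 of the 2 values shown sits, is all that is shown for it. Among the measured compounds shown here, compound 2 gives 81500 nM as the only actual number, so it has no measured neighbour to be ranked against.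

The next compound is compound 3 `COC(=O)c1[nH]c2cc(OC)ccc2c1Cc1ccccc1` with benzyl in place of isopropyl on an aromatic carbon, next to the ring atom that bears a methoxycarbonyl group. The counted difference is benzyl in place of isopropyl on an aromatic carbon and nothing else on the shared core changes.

For the measured compounds named here, no measured step gives a size for this change. Only a small move toward lower numbers is expected in this assay and it is not expected to go beyond the scatter. The estimated step is a 1.4-fold lower number from compound 2 to compound 3 (0.13 log units; within the scatter) on that basis. A report of only a limit remains possible. For compound 3 the expected value is 60000 nM with an estimated range from 15000 nM to 100000 nM in this read-out.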

Compound 3, half-maximal effective concentration: 61600 nM
For compound 3 the middle estimate is 1.0-fold (0.01 log units) below the measured one; low and high end bracket the measured number.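

In this assay, among the compounds shown here, benzyl in place of isopropyl on the aromatic carbon gives a 1.3-fold lower number from compound 2 to compound 3 (0.12 log units; within the scatter), and this is the first step with a measured size. It shows that, for this pair, adding a six-membered aromatic ring of carbon at this position, two ring bonds from the ring nitrogen, does not move the read-out beyond the scatter, so compound 2 and compound 3 cannot be ranked against each other. Compound 1 differs from the others in more than one place and is reported only as a limit, so steps involving it cannot be read: the limit of > 100000 nM in this assay, at which 1 of the 3 values shown sits.

The pair leaves open whether this position stays as flat for groups of another kind, such as an aminomethyl group, a carboxylic acid or a longer chain such as phenethyl, or whether one of these would give a step beyond the scatter. Also open, as far as these compounds go, is what the methoxy group on the shared core contributes, as a single change there, with isopropyl or benzyl held in place, would be needed to separate its share from that of the group at this position.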